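A 1,3-thiazol-2-yl group replaces 2,6-dimethoxyphenyl

The compounds below may be only part of what the source reports. "The series", "measured", "known", "first", "only" and "open" are said of these compounds alone.

In a functional assay on HOS-TE85 cells (Homo sapiens) for inhibition, read by CCK-8 assay, with a stated time of 72 h (a higher number here means a weaker inhibitor, a lower number a stronger inhibitor), compound 1 `CCN1C(=O)CSC1c1cccc(C(=O)NCCCCc2ccccc2)c1` gives > 1000 nM, which is a limit of the assay and not a number. Compound 2 `COc1cccc(OC)c1N1C(=O)CSC1c1cccc(C(=O)NCCCCc2ccccc2)c1` gives > 1000 nM, which is also a limit. Among the measured compounds shown here, the series so far therefore rests on (the limit of > 1000 nM in this assay, at which 2 of the 2 values shown sit), and compound 2 has no exact position on the scale. Compound 3 `O=C(NCCCCc1ccccc1)c1cccc(C2SCC(=O)N2c2nccs2)c1` carries 1,3-thiazol-2-yl in place of 2,6-dimethoxyphenyl on an amide-type nitrogen in a ring. For the measured compounds named here, the only measured step at this same place is a step that the two limits leave unreadable from compound 1 to compound 2, so it offers no size to carry forward. With no readable size as a guide, the expected change in this assay is a step that the limit leaves unreadable from compound 2 to compound 3, and no firm direction is foreseen. For compound 3 the estimate is 1500 nM, with an expected range from 200 nM to 8000 nM.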

Compound 3, half-maximal inhibitory concentration: > 1000 nM
Compound 3: a limit, no number (the forecaster's own chance of this, stated with the estimate: 60%); the middle value does not contradict the limit.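

No step can be read between compound 1, compound 2 and compound 3, because each value is a limit of the assay and not a number: the limit of > 1000 nM in this assay, at which 3 of the 3 values shown sit.

The compounds shown leave open how strongly each one inhibits in this assay, and whether the group on the amide-type nitrogen in a ring changes that.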